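Dropping One Fluoro Group: Expected Effect in Rats

The compounds below may be only part of what the source reports. "The series", "measured", "known", "first", "only" and "open" are said of these compounds alone.

Compound 1 `NC(=O)/C=C1\CCc2cc(Cl)ccc21` gives 30% in a functional assay on the whole organism with Rattus norvegicus as the target, at a dose of 20 mg/kg by the oral route; on this read-out lower numbers stand for less inhibition and higher numbers for more inhibition at the one dose given (going by the name of the read-out).
Compound 2 `O=C(/C=C1\CCc2c(F)cc(F)cc21)NC1CC1` gives 38% in this assay.
Compound 3 `NC(=O)/C=C1\CCc2cc(F)ccc21` gives 54% in this assay.

Among these three numbers compound 2 sits in the middle. Its value and that of compound 1 cannot be told apart within the usual scatter of such measurements, whereas the value of compound 3 lies above it by more than that scatter.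

Compound 4 `O=C(/C=C1\CCc2ccc(F)cc21)NC1CC1` differs from compound 2 in one place: hydrogen in place of fluoro on an aromatic carbon.

For the measured compounds named here, only one measured step exists, and it concerns a different change on a different core, the exchange of one halogen for another: a number 24 percentage points higher from compound 1 to compound 3 (beyond the scatter). Going by the values given here, no measured pair shows what removing a fluoro group does, so that step gives only weak guidance. A change in this assay not clearly beyond the scatter is therefore expected, with a wide range, for compound 4: a number 2 percentage points higher from compound 2 to compound 4 (within the scatter). Compound 4 is expected to give about 40%, somewhere between 20% and 60%.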

Compound 4, a percentage reported as inhibition, in the whole organism at one dose (the size of the read-out at that dose, not a potency): 5%
The estimate for compound 4 lay 35 percentage points above the measured number; the measured number lies below the stated range.
By their numbers in this assay, from the lowest: compound 4; then compounds 1 and 2 (each within the scatter of the next); then compound 3.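

Hydrogen in place of fluoro on this aromatic carbon, ortho to a fused ring and meta to a fluoro group, gives a number 33 percentage points lower from compound 2 to compound 4 (beyond the scatter) in this assay and is the first measured step to show what this position contributes. A change of one heavy atom here is enough for a large drop at the one dose given, so the fluoro group at this place matters in this pair even though compound 4 still carries its other fluoro group. Nothing available explains why this one atom makes so large a difference.

For the compounds shown here, still open is whether the other fluoro group matters as much, since no pair shows its removal. From the compounds shown here alone, it is also open how a methoxy group or an amine on this same aromatic carbon would compare with fluoro and with hydrogen.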